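Aryloxymethyl ketone series: step from compound 3 to compound 4

This account rests on a few compounds, and the source may have more. Where it says the series, first, only, none or still open, it means among the compounds named here.

Compound 1 `CC(C)[C@H](NC(=O)COc1cccc2ccccc12)C(=O)N[C@@H](CC(=O)O)C(=O)CSc1nnc(-c2ccccc2)o1` gives 150000 nM in a functional assay on Jurkat cells (Homo sapiens) for inhibition; a lower number here means a stronger inhibitor, a higher number a weaker inhibitor.
Compound 2 `CC(C)[C@H](NC(=O)COc1cccc2ccccc12)C(=O)N[C@@H](CC(=O)O)C(=O)COc1ccncn1` gives > 200000 nM, a limit of this assay.
Compound 3 `CC(C)[C@H](NC(=O)COc1cccc2ccccc12)C(=O)N[C@@H](CC(=O)O)C(=O)COc1ccnc(C(F)(F)F)n1` gives 37000 nM.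

Compound 3 holds the lowest number of the two measured values, with compound 1 nearest a 4.1-fold lower number from compound 1 to compound 3 (0.61 log units; beyond the scatter). Compound 4 `CC(C)[C@H](NC(=O)COc1cccc2ccccc12)C(=O)N[C@@H](CC(=O)O)C(=O)COc1cccc2cccnc12` differs from compound 3 by quinolin-8-yl in place of 2-(trifluoromethyl)pyrimidin-4-yl on an oxygen on a saturated carbon. Within the data shown here, the steps that bear on this change are a 4.1-fold lower number from compound 1 to compound 3 (0.61 log units; beyond the scatter) and an at least 5.4-fold lower number from compound 2 to compound 3 (0.73 log units; beyond the scatter), both ending at compound 3; the group on the oxygen governs the number, and the trifluoromethyl step was the larger gain. Compound 4 keeps a bicyclic group but lacks the trifluoromethyl, so a weaker result than compound 3 is expected, a 2.2-fold higher number from compound 3 to compound 4 (0.33 log units; beyond the scatter). Compound 4 is estimated at 80000 nM, within 20000 nM to 200000 nM.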

Compound 4, half-maximal inhibitory concentration: > 200000 nM
Compound 4 gave a limit, no number; the forecaster's own chance of this, stated with the estimate: 25%; middle value at least 2.5-fold (0.39 log units) away from the limit.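

In this assay compound 4 gives > 200000 nM, a limit of the assay. On this oxygen, a second aromatic ring does not match 2-(trifluoromethyl)pyrimidin-4-yl, with an at least 5.4-fold higher number from compound 3 to compound 4 (0.73 log units; beyond the scatter), while the comparison with the (5-phenyl-1,3,4-oxadiazol-2-yl)sulfanyl group gives only an at least 1.3-fold higher number from compound 1 to compound 4 (0.12 log units; that floor lies within the scatter). The step between the two pyrimidin-4-yl and quinolin-8-yl ethers cannot be read because both values are limits: the limit of > 200000 nM in this assay, at which 2 of the 4 values shown sit.

From the compounds shown here alone, it remains open whether trifluoromethyl on quinolin-8-yl would bring a gain like the one seen on pyrimidin-4-yl. Going by these compounds, it is also open whether a nitrile or an amine in its place on pyrimidin-4-yl would do the same.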